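Ethylamino to butylamino on the core of compound 2

The source may report more compounds than this note shows. Statements on the series, on what has been measured and on what is new or still open speak of the compounds shown alone.

Two compounds of this series carry a number in a functional assay on HT-29 cells (Homo sapiens) for cytotoxicity, read by neutral red uptake, with a stated time of 72 h; a higher number here means a weaker inhibitor, a lower number a stronger inhibitor. Compound 1, `c1ccc(CCCCNc2nc(NCCCCc3ccccc3)c3ccccc3n2)cc1`, gives 3780 nM. Compound 2, `CCNc1nc(SCC)nc2ncccc12`, gives 26200 nM in this assay, the higher of the two numbers; the gap to compound 1 lies beyond the usual scatter. The two compounds share no single point of difference, so the gap between them is noted only as what the two values show.

Compound 3, `CCCCNc1nc(SCC)nc2ncccc12`, is the next compound and awaits measurement in this assay. Its difference from compound 2 is ethyl in place of hydrogen on a saturated chain carbon, two bonds along the chain from a nitrogen on an aromatic ring; read one bond further out, the ethylamino of compound 2 becomes butylamino. Among the compounds with values here, no measured pair with this change exists. Within the data shown here, compound 1, the only compound with the lower number, carries longer chains on its amino groups, but its core is not that of compound 2, so this offers no direct guide.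

Compound 3 is expected to give 14000 nM, within 4500 nM to 45000 nM. The step that this estimate means is a 1.9-fold lower number from compound 2 to compound 3 (0.27 log units; within the scatter), expected as a modest move toward a lower number, close to the edge of the scatter.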

Compound 3, half-maximal inhibitory concentration: 25300 nM
Compound 3: the middle estimate sits 1.8-fold (0.26 log units) below what was measured, within the range that was stated.
By their numbers in this assay, from the lowest: compound 1; then compounds 3 and 2 (each within the scatter of the next).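

Within the data shown here, on the shared core, this is the first pair that differs in one place, and it gives a first reading of the amino chain: ethyl in place of hydrogen on a saturated chain carbon, two bonds along the chain from a nitrogen on an aromatic ring, gives a 1.0-fold lower number from compound 2 to compound 3 (0.02 log units; within the scatter) in this assay. Ethylamino and butylamino therefore cannot be told apart in this assay, and this extension of the chain alone does not bring the shared core to the level of compound 1 at 3780 nM. Nothing at hand bears on the reason for this result.

Open, from the compounds shown here alone, is whether a longer chain such as octyl, or an amine or a carboxylic acid at the end of this chain, would shift the number on the shared core beyond the scatter. Also open is how much of the gap to compound 1 belongs to its core and how much to its chains, since no compound shown separates the two.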